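This account rests on a few compounds, and the source may have more. Where it says the series, first, only, none or still open, it means among the compounds named here.

Working notes on the series in a functional assay on HeLa cells (Homo sapiens) for inhibition, read by sulforhodamine B assay; on this read-out lower numbers stand for stronger inhibition and higher numbers for weaker inhibition. Compound 1 `O=C1C=C(NC2CCCCC2)C(=O)c2c1nc1n2[C@H]2OC[C@@H](O)[C@H]2OC1`, with cyclohexyl on the amine nitrogen, reads > 16000 nM; this value is a limit of the assay. Compound 2 `O=C1C=C(Nc2cccc(F)c2)C(=O)c2c1nc1n2[C@H]2OC[C@@H](O)[C@H]2OC1` gives 6440 nM. Compound 3 `O=C1C=C(Nc2ccc(I)cc2)C(=O)c2c1nc1n2[C@H]2OC[C@@H](O)[C@H]2OC1` gives 4070 nM, the lower of the two actual numbers, though the gap is small: a 1.6-fold lower number from compound 2 to compound 3 (0.20 log units; within the scatter).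

Compound 4 `COc1cccc(NC2=CC(=O)c3nc4n(c3C2=O)[C@H]2OC[C@@H](O)[C@H]2OC4)c1` has 3-methoxyphenyl in place of 4-iodophenyl on an amine nitrogen.

The most relevant evidence is the only swap of one substituted phenyl for another, which stayed within the scatter, as just shown. The larger changes replace cyclohexyl with a substituted phenyl: an at least 2.4-fold lower number from compound 1 to compound 2 (0.39 log units; beyond the scatter) and an at least 3.9-fold lower number from compound 1 to compound 3 (0.59 log units; beyond the scatter). Compound 4 keeps a substituted phenyl, so these steps offer less guidance here.

No shift beyond the scatter is expected in this assay, with a slight rise as a weak lean only. The expected change is a 1.2-fold higher number from compound 3 to compound 4 (0.09 log units; within the scatter). Compound 4 is estimated at 5000 nM, with an expected range of 2200 nM to 12000 nM.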

Compound 4, half-maximal inhibitory concentration: 4280 nM
The estimate for compound 4 lay 1.2-fold (0.07 log units) above the measured number; the measured number falls inside the stated range.
By their numbers in this assay, from the lowest: compounds 3, 4 and 2 (each within the scatter of the next). At a limit, above all of these: compound 1.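

Taking out 4-iodophenyl and putting in 3-methoxyphenyl on the amine nitrogen adds a hydrogen-bond acceptor, yet this assay gives a 1.1-fold higher number from compound 3 to compound 4 (0.02 log units; within the scatter), and methoxy in place of fluoro on an aromatic carbon gives a 1.5-fold lower number from compound 2 to compound 4 (0.18 log units; within the scatter). Compounds 2, 3 and 4 therefore cannot be told apart, with fluoro, iodo and methoxy on the phenyl ring all giving readings within the scatter of one another. Replacing cyclohexyl gives an at least 3.7-fold lower number from compound 1 to compound 4 (0.57 log units; beyond the scatter), the third substituted phenyl to go beyond the scatter from compound 1, but compound 1 stands at a limit, so the true size of this step stays open: the limit of > 16000 nM in this assay, at which 1 of the 4 values shown sits.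

Because no substituent appears at both ring positions, 3-methoxyphenyl and 4-iodophenyl do not separate the effect of position from that of the group. Also open, as far as these compounds go, is whether an unsubstituted phenyl, a benzyl group, or a carboxylic acid or aminomethyl group on the phenyl ring would move the reading beyond the scatter.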